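Swapping a methallyl arm for a thienylmethyl arm

The compounds below may be only part of what the source reports. "The series", "measured", "known", "first", "only" and "open" are said of these compounds alone.

Of the compounds shown here, three with a shared core have been measured in a physicochemical assay for acid dissociation. Compound 1 `Brc1ccc(Br)c(N(CC2CC2)C2=NCCN2)c1` gives 11 in this assay. Compound 2 `Brc1cccc(N(CC2CC2)C2=NCCN2)c1Br` gives 11.1. Compound 3 `C=C(C)CN(C1=NCCN1)c1c(Br)cccc1Br` gives 10.7. The number for compound 3 differs from that of compound 1 by an amount that falls within the usual scatter, so the two cannot be ranked against each other, while its gap to compound 2 is beyond the scatter, with compound 2 giving up its proton less readily.

The next compound, compound 4 `Brc1cccc(Br)c1N(Cc1cccs1)C1=NCCN1`, has not yet been measured. It differs from compound 3 in one place: thiophen-2-yl in place of 1-methylethenyl on a saturated chain carbon bound to a nitrogen on an aromatic ring. Among the compounds with values here, no measured pair shows exactly this change, so there is nothing to anchor its effect. Since all three measured compounds sit close together, the step from compound 3 is expected to be small, no change at the digits printed from compound 3 to compound 4 (within the scatter), and not clearly beyond the scatter. For compound 4 the estimated value in this assay is 10.7, with a likely range from 10.2 to 11.2.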

Compound 4, acid dissociation constant: 10.5
The estimate for compound 4 lay 0.20 log units above the measured number; low and high end bracket the measured number.
By their numbers in this assay, from the lowest: compounds 4, 3, 1 and 2 (each within the scatter of the next, the first and the last beyond it).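

In this assay, putting thiophen-2-yl in place of 1-methylethenyl on a saturated chain carbon bound to a nitrogen on an aromatic ring gives a number 0.20 log units lower from compound 3 to compound 4 (within the scatter), so compound 3 and compound 4 cannot be ranked against each other. This first step between two measured compounds that differ in one place shows that a five-membered aromatic ring containing sulfur can replace the smaller group with its double bond while the number stays within the scatter. No supporting measurement is available to explain this result.

From the compounds shown here alone, whether an amine or a carboxylic acid at this place would give a step beyond the scatter remains open. A longer chain ending in thiophen-2-yl also remains to be read in this way.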